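Flipping one ring stereocentre in a naphthyl lactone

This account rests on a few compounds, and the source may have more. Where it says the series, first, only, none or still open, it means among the compounds named here.

Measured compounds:
- compound 1, `C=C1C(=O)O[C@H](c2ccc3ccccc3c2)[C@H]1C`: 104%
- compound 2, `C=C1C(=O)O[C@H](c2ccc(OC)cc2)[C@H]1c1ccccc1`: 73%
- compound 3, `C=C1C(=O)O[C@@H](c2ccc3ccccc3c2)[C@H]1c1ccccc1`: 113%

The measurement is a functional assay on BXPC-3 cells (Homo sapiens) for cytotoxicity, read by MTT assay, with a stated time of 72 h, tested at 1 uM (a lower number here means a stronger effect, a higher number a weaker effect of the compound at the concentration tested), where a high percentage means the cells are barely affected. Compound 3 gives the highest of the three numbers in this assay, 113%. Compound 1 is close, with a number only a few points lower and within the scatter, so the two cannot be ranked against each other. Compound 2 stands apart, with a number well beyond the scatter below compound 3, and so is the only one of the three with a clear effect at this concentration.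

Compound 4, `C=C1C(=O)O[C@H](c2ccc3ccccc3c2)[C@H]1c1ccccc1`, has not yet been measured. It differs from compound 3 as follows: the two compounds have the same atoms and bonds and differ only in configuration as drawn: 1 of 2 stereo elements differ; a stereocentre at a saturated ring carbon is drawn R in compound 3 and S in compound 4. Among the measured compounds shown here, no measured pair shows what such a change in configuration alone does here. For the measured compounds named here, with no step to lean on, the step from compound 3 to compound 4 is expected to be small, a number 13 percentage points lower from compound 3 to compound 4 (beyond the scatter), most likely within the scatter and perhaps leaning slightly lower. Compound 4 is therefore expected to give about 100%, with a range from 72% to 118%.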

Compound 4, a percentage reported as activity, at one concentration (the size of the read-out at that concentration, not a potency): 60%
Beside the measured number, compound 4's estimate is 40 percentage points above it, outside the stated range (below it).
By their numbers in this assay, from the lowest: compound 4; then compound 2; then compounds 1 and 3 (each within the scatter of the next).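

Configuration at this saturated ring carbon matters on its own in this assay: inverting it gives a number 53 percentage points lower from compound 3 to compound 4 (beyond the scatter). This large step can be tied to the stereocentre, because nothing else separates the two compounds: the fact that compounds 3 and 4 differ only in the configuration as drawn

The group on a saturated ring carbon also counts, as phenyl in place of methyl gives a number 44 percentage points lower from compound 1 to compound 4 (beyond the scatter), although this rests on a single pair and says nothing about that change in the other configuration.

Going by these compounds, it remains open whether the second stereocentre has a similar influence, and whether an amine or a longer chain in place of phenyl would keep the effect. A reading at one concentration also gives the size of the effect at that concentration only, and leaves open how compound 4 behaves at any other.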